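The compounds below may be only part of what the source reports. "The series", "measured", "known", "first", "only" and "open" are said of these compounds alone.

Measured so far:
Compound 1 `OC(c1ccccc1)c1c(C(F)(F)F)nc2ccc(Br)cc2c1Br`: 6.26 in a physicochemical assay for lipophilicity; on this read-out lower numbers stand for lower lipophilicity and higher numbers for higher lipophilicity
Compound 2 `COc1cccc(NC(=O)Nc2ccc3nc(Oc4ccc(F)cc4C(C)O)c(Cc4ccccc4)cc3c2)c1`: 6.72 in this assay

Of the two numbers, compound 2 stands highest; compound 1 sits lower by a gap beyond the usual scatter. The account now follows the change from compound 2 to compound 3 `COc1cccc(NC(=S)Nc2ccc3nc(Oc4ccc(F)cc4C(C)O)c(Cc4ccccc4)cc3c2)c1`, in which the structures differ as follows: a group of 11 heavy atoms (8 carbon, 1 nitrogen, 1 oxygen, 1 sulfur; one six-membered aromatic ring of carbon only) in place of a group of 11 heavy atoms (8 carbon, 1 nitrogen, 2 oxygen; one six-membered aromatic ring of carbon only), on a nitrogen on an aromatic ring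

Among the measured compounds shown here, no step between two measured compounds is available to lean on here, so the expectation rests on the structural change alone. The expected step of a number 0.38 log units higher from compound 2 to compound 3 (beyond the scatter) is a modest rise, beyond the scatter. Compound 3 is therefore estimated at 7.1 in this assay, within a range from 6.6 to 7.6.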

Compound 3, partition coefficient: 7.86
Beside the measured number, compound 3's estimate is 0.76 log units below it; the measured number lies above the stated range.
By their numbers in this assay, from the lowest: compound 1; then compound 2; then compound 3.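

Among the compounds shown here, at this place, on a nitrogen on an aromatic ring, exchanging the (3-methoxyphenyl)carbamoyl group for its sulfur-bearing counterpart gives a number 1.14 log units higher from compound 2 to compound 3 (beyond the scatter) in this assay and is the first single change tied to a measured step. The two groups have the same heavy-atom count and the same hydrogen-bond donor and acceptor counts, yet the read-out separates them clearly. Nothing at hand accounts for the size of this step. Going by these compounds, it remains open whether a sulfonyl or acetyl group on this nitrogen would shift the number in the same direction, and whether the same exchange would give a step of similar size on another core.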